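Compound 4: one methoxy fewer than compound 3

This account rests on a few compounds, and the source may have more. Where it says the series, first, only, none or still open, it means among the compounds named here.

In a functional assay on HT-29 cells (Homo sapiens) for antiproliferative activity, read by sulforhodamine B assay, with a stated time of 48 h (on this read-out lower numbers stand for stronger inhibition and higher numbers for weaker inhibition), compound 3 `COc1ccc(OS(=O)(=O)c2ccc(N3CCN(C)C3=O)cc2)cc1OC` gives 12000 nM, the highest of the three numbers and beyond the scatter of the other two: compound 1 `CCc1ccccc1OS(=O)(=O)c1ccc(N2CCN(C)C2=O)cc1` gives 4600 nM and compound 2 `Cc1ccc(OS(=O)(=O)c2ccc(N3CCN(C)C3=O)cc2)c(C)c1` gives 3000 nM. Compound 4 `COc1ccc(OS(=O)(=O)c2ccc(N3CCN(C)C3=O)cc2)cc1` has hydrogen in place of methoxy on an aromatic carbon, ortho to a methoxy group and meta to a large group (hydrogen in place of methoxy on an aromatic carbon). Among the measured compounds shown here, the only measured step, a 1.5-fold lower number from compound 1 to compound 2 (0.19 log units; within the scatter), involves no methoxy, and no measured step removes one. Compound 1, at 4600 nM, and compound 2, at 3000 nM, carry no methoxy, which weakly suggests a lower number. The expected change is a 2.0-fold lower number from compound 3 to compound 4 (0.30 log units; within the scatter), a modest step. For compound 4 the estimate is 6000 nM, with an expected range of 2000 nM to 14000 nM.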

Compound 4, half-maximal inhibitory concentration: > 100000 nM
Compound 4 gave a limit, no number; the forecaster's own chance of this, stated with the estimate: 5%; middle value at least 16-fold (1.22 log units) from the limit.
By their numbers in this assay, from the lowest: compounds 2 and 1 (each within the scatter of the next); then compound 3. At a limit, above all of these: compound 4.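

Compound 4 gives a limit, not a number: the limit of > 100000 nM in this assay, at which 1 of the 4 values shown sits. This position, ortho to a methoxy group, does not tolerate the change: hydrogen in place of methoxy gives an at least 8.3-fold higher number from compound 3 to compound 4 (0.92 log units; beyond the scatter) and the read-out leaves the measurable range. The aryl group on the oxygen also matters strongly, with an at least 33-fold higher number from compound 2 to compound 4 (1.52 log units; beyond the scatter) for 4-methoxyphenyl in place of 2,4-dimethylphenyl and an at least 21-fold higher number from compound 1 to compound 4 (1.33 log units; beyond the scatter) for 4-methoxyphenyl in place of 2-ethylphenyl.

As far as these compounds go, it remains open whether a hydroxy, an amine or a chlorine at this position gives a number in this assay as the methoxy of compound 3 does.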